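From Methoxy to Phenoxy at the Assay Limit

A few compounds are considered here, and "the series" means these few. Any claim that something is new, unique, unknown or untested is made for them only; others in the source may bear on it.

In an ADME assay on HepG2 cells (Homo sapiens) for cytotoxicity, read by luminescence, with a stated time of 72 h (on this read-out lower numbers stand for an effect already at smaller amounts and higher numbers for an effect only at larger amounts of compound), compound 1 (`CCOC(=O)c1c(-c2cc(OC)cc(OC)c2)[nH]c2cc(OC)ccc2c1=O`) gives > 21500 nM as a limit of the assay. Compound 2 (`CCOC(=O)c1c(-c2cccc(OC(F)(F)F)c2)[nH]c2cc(OC(F)(F)F)ccc2c1=O`) gives > 21500 nM as a limit too. Compound 3 (`CCOC(=O)c1c(-c2cccc(OC)c2)[nH]c2cc(F)cc(F)c2c1=O`) gives > 21500 nM as a limit as well, which places it at the limit of > 21500 nM in this assay, at which 3 of the 3 values shown sit, without a number of its own. Compound 4 (`CCOC(=O)c1c(-c2cccc(Oc3ccccc3)c2)[nH]c2cc(F)cc(F)c2c1=O`) departs from compound 3 in one place, methoxy to phenoxy, with phenyl in place of methyl on an oxygen on an aromatic ring. For the measured compounds named here, no measured step guides the size of the change, so in this assay only a small move toward lower numbers is expected, possibly none beyond the scatter. The expected change is an at least 1.0-fold lower number from compound 3 to compound 4 (0.03 log units; that floor lies within the scatter) in this estimate. The estimate for compound 4 is 20000 nM with an expected range of 9000 nM to 45000 nM and a fair chance of another limit.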

Compound 4, half-maximal effective concentration: > 21500 nM
Compound 4: only a limit was reported (the forecaster's own chance of this, stated with the estimate: 65%); middle value at least 1.0-fold (0.03 log units) away from the limit.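

Compound 3 and compound 4 both give only a limit in this assay, so no step between them can be read: the limit of > 21500 nM in this assay, at which 4 of the 4 values shown sit.

The compounds shown leave open whether methoxy to phenoxy changes this read-out at all.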